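A Second Chloro Group: Expected Effect on Cytotoxicity

The source may report more compounds than this note shows. Statements on the series, on what has been measured and on what is new or still open speak of the compounds shown alone.

For the measured compounds named here, compound 2 `ClCc1cccc(Cn2cnc3c(Cl)ncnc32)c1` is the only compound in this small set for which a number exists; in a functional assay on HOP-92 cells (Homo sapiens) for cytotoxicity, read by sulforhodamine B assay, with a stated time of 48 h (on this read-out higher numbers stand for lower toxicity in this test and lower numbers for higher toxicity in this test), compound 2 gives 31600 nM. Compound 1 `ClCc1ccccc1Cn1cnc2c(Cl)nc(Cl)nc21` carries no number in this assay, where the entry for compound 1 reads "not determined" (no result reported). Compound 3 `ClCc1ccc(Cn2cnc3nc(Cl)nc(Cl)c32)cc1` likewise carries no number in this assay, where the entry for compound 3 reads "not determined" (no result reported). Compound 4 `ClCc1cccc(Cn2cnc3c(Cl)nc(Cl)nc32)c1` differs from compound 2 in a single place: chloro in place of hydrogen on an aromatic carbon. Going by the values given here, no measured pair shows what such a change does in this assay, so no step size is known from the data, and the one value of compound 2 is the only anchor. Compound 4 is therefore expected to stay near compound 2, with a step estimated as a 1.3-fold lower number from compound 2 to compound 4 (0.10 log units; within the scatter), not clearly beyond the usual scatter in either direction. The estimate for compound 4 in this assay is 25000 nM, within a range from 8000 nM to 80000 nM.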

Compound 4, concentration lethal to 50% of the cells: 7080 nM
Compound 4: the middle estimate sits 3.5-fold (0.55 log units) above what was measured; measured number outside the range, below it.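

Chloro in place of hydrogen, on the aromatic carbon between two ring nitrogen atoms, is the first change in this set with a readable effect in this assay: the data show a 4.5-fold lower number from compound 2 to compound 4 (0.65 log units; beyond the scatter), a modest step toward higher toxicity in this test. For the compounds shown here, the single earlier value could not show that this position responds to substitution at all. Nothing available explains why the number falls.

Steps involving compound 1 and compound 3 cannot be read. As far as these compounds go, whether an amine or a methoxy group at this position would shift the number in the same direction remains open.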